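Swapping cyclopropyl for a chlorinated benzothiophene

The source may hold more compounds than are shown below. What is called first, only, known or untested is meant among the compounds shown, and "the series" means these compounds.

Values from a toxicity assay on GES1 cells (Homo sapiens) for inhibition, read by MTT assay, with a stated time of 72 h (on this read-out higher numbers stand for weaker inhibition and lower numbers for stronger inhibition), are set out here

- Compound 1 `Cc1cc(N2CC[C@@H](C)[C@@H](N(C)c3ncnc4[nH]ccc34)C2)n2nc(SCc3ccc(Cl)cc3)nc2n1` gives > 100000 nM as a limit of the assay and not a number
- Compound 2 `Cc1cc(N2CC[C@@H](C)[C@@H](N(C)c3ncnc4[nH]ccc34)C2)n2nc(SCC3CC3)nc2n1` gives 27900 nM
- Compound 3 `Cc1nc2nc(SCc3ccc(Cl)cc3)nn2c(N2CC[C@@H](C)[C@@H](N(C)c3ncnc4[nH]ccc34)C2)c1C` gives 99200 nM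

Only two of these entries are true numbers. Compound 2 holds the lower one at 27900 nM and so shows the stronger inhibition of the pair, while compound 3 gives 99200 nM as the higher one.

The next compound changes one group of compound 2. Compound 4 `Cc1cc(N2CC[C@@H](C)[C@@H](N(C)c3ncnc4[nH]ccc34)C2)n2nc(SCc3csc4ccc(Cl)cc34)nc2n1` carries 5-chloro-1-benzothiophen-3-yl in place of cyclopropyl on a saturated chain carbon bound to a sulfur, and the count of that change reads 5-chloro-1-benzothiophen-3-yl in place of cyclopropyl on a saturated chain carbon bound to a sulfur in full.

Among the measured compounds shown here, one measured step bears directly on this: an at least 3.5-fold lower number from compound 1 to compound 2 (0.55 log units; beyond the scatter). There, cyclopropyl replaced 4-chlorophenyl at the same place, whereas the new change runs the other way, with cyclopropyl leaving and a chlorine-bearing aromatic group entering. The second step, a number no higher from compound 1 to compound 3 (the limit leaves the size open), concerns a methyl in place of hydrogen on an aromatic carbon and adds little.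

A move back toward higher numbers, meaning weaker inhibition, is therefore expected in this assay, and the assay may report only a limit. The expected size is a 2.7-fold higher number from compound 2 to compound 4 (0.43 log units; beyond the scatter) in this estimate. Compound 4 is estimated at 75000 nM, with an expected range from 30000 nM to 100000 nM.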

Compound 4, half-maximal inhibitory concentration: > 100000 nM
Compound 4: only a limit was reported; the forecaster's own chance of this, stated with the estimate: 45%; at least 1.3-fold (0.12 log units) between middle value and limit.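

In this assay, putting 5-chloro-1-benzothiophen-3-yl in place of cyclopropyl gives an at least 3.5-fold higher number from compound 2 to compound 4 (0.55 log units; beyond the scatter), which means weaker inhibition of these cells. Read with an at least 3.5-fold lower number from compound 1 to compound 2 (0.55 log units; beyond the scatter), this shows that the contrast at this place on a saturated chain carbon bound to a sulfur is not confined to 4-chlorophenyl: in this series, two different chlorine-bearing aromatic groups both give higher numbers than cyclopropyl. The true size of the new step stays hidden, since compound 4 gives only a limit of the assay and not a number: the limit of > 100000 nM in this assay, at which 2 of the 4 values shown sit.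

The step between 4-chlorophenyl and 5-chloro-1-benzothiophen-3-yl cannot be read, as both entries are limits, so these two aromatic groups cannot be ranked against each other. As far as these compounds go, it also remains open whether a small non-aromatic group of another kind, such as an amine, a carboxylic acid or a longer chain, would keep the number close to compound 2 at 27900 nM or push it up.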